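A few compounds are considered here, and "the series" means these few. Any claim that something is new, unique, unknown or untested is made for them only; others in the source may bear on it.

Measured compounds:
- compound 1, `COc1cccc(-c2nc3c(-c4ccc(Cl)cc4)n[nH]c3c(=O)n2NC(=O)c2ccccc2)c1`, in a functional assay on DU-145 cells (Homo sapiens) for cytotoxicity, read by sulforhodamine B assay, with a stated time of 2 days, tested at 100 uM (a lower number here means less inhibition, a higher number more inhibition at the concentration tested (going by the name of the read-out)), gives 94.1%
- compound 2, `O=C(Nn1c(CCc2ccccc2)nc2c(-c3ccc(Cl)cc3)n[nH]c2c1=O)c1ccccc1`, in this assay gives 85.6%

Compound 2 holds the lower of the two numbers in this assay, and its nearest neighbour is compound 1, whose value lies higher by a number 8.5 percentage points lower from compound 1 to compound 2 (within the scatter), a gap that stays within the scatter; the two compounds are therefore not told apart on these data. Compound 3, `CCCCc1nc2c(-c3ccc(Cl)cc3)n[nH]c2c(=O)n1NC(=O)c1ccccc1`, has not yet been measured. It differs from compound 2 by ethyl in place of phenyl on a saturated chain carbon, two bonds along the chain from an aromatic carbon. Within the data shown here, the only step available for comparison is the one from compound 1 to compound 2, in which a phenethyl chain replaced 3-methoxyphenyl and the read-out in this assay moved by a number 8.5 percentage points lower from compound 1 to compound 2 (within the scatter), that is, not beyond the scatter. That step concerns a different part of the same side chain, so it gives only weak guidance. The account expects the change from compound 2 to compound 3 to yield a step of about a number 7.6 percentage points lower from compound 2 to compound 3 (within the scatter) in this assay, downward but with a wide uncertainty. For compound 3 the estimate in this assay is 78%, expected to fall between 55% and 95%.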

Compound 3, a percentage reported as inhibition, at one concentration (the size of the read-out at that concentration, not a potency): 93.1%
Compound 3: the middle estimate sits 15.1 percentage points below what was measured; the measured number falls inside the stated range.
By their numbers in this assay, from the lowest: compounds 2, 3 and 1 (each within the scatter of the next).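

In this assay, ethyl in place of phenyl on a saturated chain carbon, two bonds along the chain from an aromatic carbon, gives a number 7.5 percentage points higher from compound 2 to compound 3 (within the scatter), so on these data the phenyl of compound 2 is not shown to matter for the read-out at this position. Butyl in place of 3-methoxyphenyl on an aromatic carbon gives a number 1 percentage points lower from compound 1 to compound 3 (within the scatter), which shows that among these three compounds a chain with no ring cannot be told apart from either of the two groups that carry a six-membered aromatic ring. Nothing at hand explains why these groups read alike.

Whether a shorter chain such as methyl, a longer chain such as hexyl, or an amine at the end of the butyl chain would stay within the scatter of these compounds remains open. From the compounds shown here alone, with only one tested concentration, it is also open whether compounds that cannot be told apart here would separate at a lower concentration.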